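Vinyl for methyl on the chain carbon: compound 4

The source may hold more compounds than are shown below. What is called first, only, known or untested is meant among the compounds shown, and "the series" means these compounds.

Compound 2 `CCCc1nc(C)c2cnn(CC)c(=O)n12` sits at the limit of a functional assay for inhibition, with Homo sapiens as the target; a higher number here means a weaker inhibitor, a lower number a stronger inhibitor: in this assay compound 2 gives > 48000 nM, a limit rather than a number. Compound 3 `CCCc1nc(C)c2c(C)nn(CC)c(=O)n12` likewise gives the limit > 48000 nM in this assay. For the measured compounds named here, the single one-place step, a step that the two limits leave unreadable from compound 2 to compound 3, therefore has no readable size, as the limit of > 48000 nM in this assay, at which 2 of the 3 values shown sit, shows. Going by the values given here, compound 1 `Oc1nnc(Br)c2c(Br)nc(Br)n12` gives 27000 nM in this assay, but no one-place step joins it to compound 2. Compound 4 `C=CCn1ncc2c(C)nc(CCC)n2c1=O` differs from compound 2 by vinyl in place of methyl on a saturated chain carbon bound to an aromatic nitrogen. Among the compounds with values here, no measured step bears on this change and the starting point is itself a limit, so the expected step that the limit leaves unreadable from compound 2 to compound 4 is none beyond the scatter, with compound 4 expected to stay at the limit. The estimate for compound 4 in this assay is 60000 nM, expected between 25000 nM and 150000 nM.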

Compound 4, half-maximal inhibitory concentration: 40000 nM
Compound 4: the middle estimate sits 1.5-fold (0.18 log units) above what was measured, within the range that was stated.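

In this assay, for the compounds shown here, the change of ethyl to allyl, on a saturated chain carbon bound to an aromatic nitrogen, gives the first one-place step with a readable floor, an at least 1.2-fold lower number from compound 2 to compound 4 (0.07 log units; that floor lies within the scatter), so no real gain can be claimed from it. From the compounds shown here alone, the full size of the step stays unknown because compound 2 carries only a limit: the limit of > 48000 nM in this assay, at which 2 of the 4 values shown sit.

Going by these compounds, whether a longer chain or an amine in place of allyl would move the value beyond the scatter stays open. So does whether allyl behaves alike on the core of compound 3.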